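The compounds below may be only part of what the source reports. "The series", "measured", "known", "first", "only" and "open" are said of these compounds alone.

Compound 1 `CC(O)C1C(=O)NC1OC(=O)/C=C/c1ccccc1` gives 1590 nM in a functional assay on A549 cells (Homo sapiens) for inhibition, read by MTT assay; on this read-out higher numbers stand for weaker inhibition and lower numbers for stronger inhibition. Compound 2 `CC(O)C1C(=O)NC1OC(=O)/C=C/c1ccc(N)cc1` carries an amino group where compound 1 has hydrogen on the aromatic ring, and in this assay compound 2 gives 1590 nM. Within the data shown here, the step of no change at the digits printed from compound 1 to compound 2 (within the scatter) shows that adding amino at that aromatic carbon left the read-out where it was, so compound 2 stands level with compound 1 on the numbers so far, and no measured compound lies apart from the pair.

Compound 3 `CC(O)C1C(=O)NC1OC(=O)/C=C/c1ccc(Cl)cc1` is the next compound, differing from compound 2 by chloro in place of amino on an aromatic carbon. Among the measured compounds shown here, the only measured step that bears on this change is the one from hydrogen to amino at the same aromatic carbon, which was flat within the scatter; there is no measured example of a halogen at that place. For the measured compounds named here, with one flat step as the sole guide, compound 3 is expected to lie close to compound 2, with a step of no change at the digits printed from compound 2 to compound 3 (within the scatter) in this assay, meaning no change beyond the scatter. Compound 3 is therefore estimated at 1590 nM, with a range from 700 nM to 3600 nM.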

Compound 3, half-maximal inhibitory concentration: 1590 nM
The estimate for compound 3 equals the measured number at the digits printed; low and high end bracket the measured number.
By their numbers in this assay, from the lowest: compounds 1, 2 and 3 (each within the scatter of the next).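

In this assay, the first halogen at this aromatic carbon, para to a large group, gives no change at the digits printed from compound 2 to compound 3 (within the scatter) when chloro replaces amino, and no change at the digits printed from compound 1 to compound 3 (within the scatter) when chloro replaces hydrogen. Among these compounds, the position now holds three different substituents at one level, and this includes an exchange in which the hydrogen-bond donor and hydrogen-bond acceptor counted for amino leave and chloro brings neither, so the flat result no longer rests on the single step from hydrogen to amino. No measured evidence accounts for this flat result.

The compounds shown leave open whether the read-out stays level with other groups at this carbon, such as a carboxylic acid, a nitrile, a methoxy group or a longer chain, since all three substituents here are small and together span only hydrogen, amino and chloro. They also leave open whether a substituent at another carbon of the aromatic ring, or a change elsewhere in the shared core, would move the number in a way that these three compounds cannot show.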